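Swapping benzyloxy for 5-methoxypyridin-2-yl in compound 3

A few compounds are considered here, and "the series" means these few. Any claim that something is new, unique, unknown or untested is made for them only; others in the source may bear on it.

For the measured compounds named here, in an ADME assay on microsomes from liver (Rattus norvegicus) for metabolic stability (a higher number here means that the compound lasts longer, a lower number that the compound disappears faster), compound 3 `COc1cc(OCc2cccc(OCc3ccccc3)c2)c2cc(-c3cn4nc(OC)sc4n3)oc2c1` gives 0.333 h, the lower of the two exact numbers available so far. The nearest number belongs to compound 2 `COc1cc(OCc2cccc(-c3ccc(C#N)cn3)c2)c2cc(-c3cn4nc(OC)sc4n3)oc2c1`, at 0.833 h. Compound 1 `COc1cc(OCc2cccc(-c3ccc(C(F)(F)F)cn3)c2)c2cc(-c3cn4nc(OC)sc4n3)oc2c1` gives only a limit of the assay, > 2 h.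

Compound 4 `COc1ccc(-c2cccc(COc3cc(OC)cc4oc(-c5cn6nc(OC)sc6n5)cc34)c2)nc1` keeps the shared core of compound 3 and changes one group, with 5-methoxypyridin-2-yl in place of benzyloxy on an aromatic carbon.

Two measured steps involve a similar exchange, and both run from a substituted pyridin-2-yl group to benzyloxy. The first is an at least 6.0-fold lower number from compound 1 to compound 3 (0.77 log units; beyond the scatter), and the second is a 2.5-fold lower number from compound 2 to compound 3 (0.40 log units; beyond the scatter). Read backwards, they suggest that leaving benzyloxy for a pyridin-2-yl group should raise the number in this assay. The group on the pyridine ring also counts, as shown by an at least 2.4-fold lower number from compound 1 to compound 2 (0.38 log units; beyond the scatter). Going by the values given here, no measured compound carries the methoxy version, so the closest guide is the smaller step, the one involving compound 2 at 0.833 h.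

The expected change is a 2.1-fold higher number from compound 3 to compound 4 (0.32 log units; beyond the scatter), a modest rise. For compound 4 the estimated half-life is 0.7 h, with an expected range from 0.35 h to 1.5 h.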

Compound 4, half-life: 0.317 h
Compound 4: the middle estimate sits 2.2-fold (0.34 log units) above what was measured; the whole stated range lies above it.
By their numbers in this assay, from the lowest: compounds 4 and 3 (each within the scatter of the next); then compound 2. At a limit, above all of these: compound 1.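

In this assay, moving from benzyloxy to a pyridin-2-yl ring gives no readable change when that ring carries methoxy, with a 1.1-fold lower number from compound 3 to compound 4 (0.02 log units; within the scatter), so the ring alone does not account for the higher numbers of compound 1 and compound 2. Among the three compounds that share the pyridine ring, the group on that ring is what separates them: cyano gives way to methoxy with a 2.6-fold lower number from compound 2 to compound 4 (0.42 log units; beyond the scatter), and trifluoromethyl gives way to methoxy with an at least 6.3-fold lower number from compound 1 to compound 4 (0.79 log units; beyond the scatter). That last step is only a bound on the true gap, not a measured gap, as compound 1 stands at a limit of the assay: the limit of > 2 h in this assay, at which 1 of the 4 values shown sits.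

The compounds shown leave open where other groups on the pyridine ring, such as a chlorine atom, a methyl or an amine, would fall relative to methoxy, cyano and trifluoromethyl. They also cannot tell how far compound 1 lies past its limit, or what happens chemically to any of these compounds during the incubation.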